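Triazole substituent swap on the butenolide series

The source may hold more compounds than are shown below. What is called first, only, known or untested is meant among the compounds shown, and "the series" means these compounds.

Measured so far in a functional assay on MCF7 cells (Homo sapiens) for antiproliferative activity, read by MTT assay, with a stated time of 72 h; on this read-out higher numbers stand for weaker inhibition and lower numbers for stronger inhibition:
- compound 1 `O=C1O[C@H]([C@@H](O)Cn2cc(-c3ccc(Br)cc3)nn2)C(OCc2ccccc2)=C1OCc1ccccc1` gives 5620 nM
- compound 2 `Cc1ccc(-c2cn(C/C=C3\OC(=O)C(OCc4ccccc4)=C3OCc3ccccc3)nn2)cc1` gives > 100000 nM, which is a limit of this assay and not a number

Compound 1 stands as the only number shown in this assay. Among the compounds with values here, the other entry, for compound 2, is a limit (the limit of > 100000 nM in this assay, at which 1 of the 2 values shown sits), so no step between measured compounds can be drawn here, and the two values show only that compound 1 has a measured number where compound 2 does not.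

Compound 3 `O=C1O[C@H]([C@@H](O)Cn2cc(CNS(=O)(=O)c3ccc(F)cc3)nn2)C(OCc2ccccc2)=C1OCc1ccccc1`, not yet measured, differs from compound 1 in one place: (((4-fluorophenyl)sulfonyl)amino)methyl in place of 4-bromophenyl on an aromatic carbon. The shared core of compound 1, with its hydroxyl and both benzyloxy groups, is kept unchanged. Within the data shown here, with no measured step in this assay to lean on, the expectation rests on compound 1 alone; the step from compound 1 to compound 3 is expected to be modest, toward weaker inhibition, a 2.1-fold higher number from compound 1 to compound 3 (0.33 log units; beyond the scatter). Compound 3 is therefore estimated at 12000 nM, within a range from 3000 nM to 60000 nM.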

Compound 3, half-maximal inhibitory concentration: 26800 nM
Estimate against measurement, compound 3: 2.2-fold (0.35 log units) below; measured number inside the range.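

In this assay, this aromatic carbon of the five-membered aromatic ring with 3 nitrogen gives the series its first readable step, a 4.8-fold higher number from compound 1 to compound 3 (0.68 log units; beyond the scatter), and compound 3 keeps a measured number, 26800 nM. The position therefore accepts (((4-fluorophenyl)sulfonyl)amino)methyl in place of 4-bromophenyl with a cost beyond the scatter, but this single step changes several things together: the group grows, it gains a hydrogen-bond donor and hydrogen-bond acceptors, and its aromatic ring is no longer attached directly to the ring carbon, so the step cannot be assigned to any one of these features. No measured property in hand accounts for the loss.

Within the data shown here, compound 2, at > 100000 nM, is a limit of the assay and not a number, so no step to it can be read. Still open, as far as these compounds go, is how a plain phenyl, an aminomethyl or a carboxylic acid on this same aromatic carbon would compare with compound 1 and compound 3, which would show whether the bromine, the aromatic ring or the sulfonyl amino link sets the number.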